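Dimethylamino in place of hydrogen on compound 2

The source may hold more compounds than are shown below. What is called first, only, known or untested is meant among the compounds shown, and "the series" means these compounds.

Going by the values given here, the series so far holds compound 1 (`Cc1ccc(-c2cc(/N=C3/NC(=O)CS3)cs2)cc1`) and compound 2 (`O=C1N/C(=N/c2csc(-c3ccc(Cl)cc3)c2)S/C1=C\c1ccccc1`), and neither has yet given a number. In a functional assay on MCF7 cells (Homo sapiens) for cytotoxicity, read by MTT assay, with a stated time of 72 h (a lower number here means a stronger inhibitor, a higher number a weaker inhibitor), compound 1 gives > 50000 nM as a limit of the assay and not a number. Compound 2 gives > 50000 nM here, which is likewise a limit. Among the compounds with values here, the record therefore stands at the limit of > 50000 nM in this assay, at which 2 of the 2 values shown sit, and offers no measured step to size a change by.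

Compound 3 (`CN(C)c1ccc(/C=C2\S/C(=N\c3csc(-c4ccc(Cl)cc4)c3)NC2=O)cc1`) keeps the frame of compound 2 and changes one place, phenyl to 4-(dimethylamino)phenyl, with dimethylamino in place of hydrogen on an aromatic carbon. The expected change, an at least 1.6-fold lower number from compound 2 to compound 3 (0.22 log units; that floor lies within the scatter) in this assay, is small and toward stronger inhibition, and a second limit reading would be no surprise. The expectation rests on compound 2 alone, with its limit > 50000 nM as the only anchor. The estimate for compound 3 is 30000 nM with an expected range from 8000 nM to 50000 nM on this read-out.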

Compound 3, half-maximal inhibitory concentration: 400 nM
Compound 3: middle estimate off by 75-fold (1.88 log units), on the high side; measured number below the stated range.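

In this assay, going by these compounds alone, dimethylamino in place of hydrogen on an aromatic carbon, para to a large group, gives an at least 120-fold lower number from compound 2 to compound 3 (2.09 log units; beyond the scatter), and with it the first measured number. As far as these compounds go, compound 2 gives > 50000 nM, which is a limit of the assay and not a number, so the printed size of the step is a floor and its full size stays unknown. Within the data shown here, this phenyl to 4-(dimethylamino)phenyl change therefore marks the group's position as one where a single substituent separates a reading at the limit from a measured value, something the earlier compounds could not show, as both sat at the same limit: the limit of > 50000 nM in this assay, at which 2 of the 3 values shown sit.

From the compounds shown here alone, with one substituent at one position there is no trend yet, and it remains open whether the step belongs to dimethylamino in particular or would also appear with methoxy, a primary amine or a pyrrolidine ring in the same place. Also open, going by these compounds, is whether dimethylamino would give a comparable step on another carbon of the same phenyl ring, or on the frame of compound 1, which lacks this phenyl group.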